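Ethoxy for Methyl on a Weak Cytotoxicity Read-out

The source may report more compounds than this note shows. Statements on the series, on what has been measured and on what is new or still open speak of the compounds shown alone.

compound 1, `Cc1cccc(/C=C/C(=O)c2c(O)cc(C)oc2=O)c1`: 100000 nM
compound 2, `COc1ccc(OC)c(/C=C/C(=O)c2c(O)cc(C)oc2=O)c1`: 100000 nM
compound 3, `Cc1ccc(/C=C/C(=O)c2c(O)cc(C)oc2=O)cc1`: > 100000 nM

In an ADME assay on HEK293 cells (Homo sapiens) for cytotoxicity, read by MTT assay (on this read-out higher numbers stand for weaker inhibition and lower numbers for stronger inhibition), compound 1 gives 100000 nM. Compound 2 gives 100000 nM in this assay, level with compound 1 at the digits shown and within the scatter. For compound 3 the value of > 100000 nM is a limit of the assay and not a number, as noted in the limit of > 100000 nM in this assay, at which 1 of the 3 values shown sits. Among the measured compounds shown here, all three numbers therefore sit at the top of the measured range, and no compound can be ranked against another.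

Compound 4, `CCOc1cccc(/C=C/C(=O)c2c(O)cc(C)oc2=O)c1`, differs from compound 1 by ethoxy in place of methyl on an aromatic carbon. For the measured compounds named here, no measured pair among the three compounds shows a step of this kind. Compound 1 gives 100000 nM and compound 2 gives 100000 nM in this assay, so the expected step of no change at the digits printed from compound 1 to compound 4 (within the scatter) is none beyond the scatter. Compound 4 is accordingly estimated at 100000 nM, with a range from 50000 nM to 200000 nM, and there is a fair chance that this assay again reports only a limit for it.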

Compound 4, half-maximal inhibitory concentration: 80000 nM
Compound 4: the middle estimate sits 1.3-fold (0.10 log units) above what was measured; the range from low to high includes it.
By their numbers in this assay, from the lowest: compounds 4, 1 and 2 (each within the scatter of the next).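

In this assay, ethoxy in place of methyl on an aromatic carbon, meta to a large group, gives a 1.3-fold lower number from compound 1 to compound 4 (0.10 log units; within the scatter). Among the compounds shown here, this is the first comparison in the set between compounds that differ in one place, and it shows that this position takes ethoxy without a step beyond the scatter on this read-out. Compound 3 remains a limit of the assay and not a number, so it cannot be set against this step: the limit of > 100000 nM in this assay, at which 1 of the 4 values shown sits.

Going by these compounds, whether an amine, a carboxylic acid or a longer alkoxy chain at this position would move the number beyond the scatter stays open. With only this one step, the compounds shown also leave open whether ethoxy would behave the same way on another carbon of the ring.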